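Compound 3 to compound 4: 3-chloro-4-hydroxyphenyl for 2,4-dichlorophenyl

The compounds below may be only part of what the source reports. "The series", "measured", "known", "first", "only" and "open" are said of these compounds alone.

Of the compounds shown here, three on the shared core have been read in a functional assay on HT-1080 cells (Homo sapiens) for cytotoxicity, read by MTT assay, with a stated time of 72 h; on this read-out lower numbers stand for stronger inhibition and higher numbers for weaker inhibition: compound 1 `COc1cccc(/C=C2\CCC/C(=C\c3ccccc3Cl)C2=O)c1OC`, compound 2 `COc1cccc(/C=C2\CCC/C(=C\c3cccc(O)c3)C2=O)c1OC` and compound 3 `COc1cccc(/C=C2\CCC/C(=C\c3ccc(Cl)cc3Cl)C2=O)c1OC`. Compound 1 gives 11700 nM. Compound 2 gives 8500 nM. Their step is a 1.4-fold lower number from compound 1 to compound 2 (0.14 log units; within the scatter).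

Compound 3 gives > 20000 nM, which is a limit of the assay and not a number. It stands at the limit of > 20000 nM in this assay, at which 1 of the 3 values shown sits.

Compound 4 `COc1cccc(/C=C2\CCC/C(=C\c3ccc(O)c(Cl)c3)C2=O)c1OC` carries 3-chloro-4-hydroxyphenyl in place of 2,4-dichlorophenyl on a double-bonded chain carbon bound to a double-bonded ring carbon.

Among the compounds with values here, the nearest precedent is an at least 2.3-fold higher number from compound 2 to compound 3 (0.37 log units; beyond the scatter), which leaves a 3-hydroxyphenyl for the same 2,4-dichlorophenyl and so runs opposite to the step at hand. The other relevant step is an at least 1.7-fold higher number from compound 1 to compound 3 (0.23 log units; that floor lies within the scatter). Both rest on the limit of compound 3, so they give only floors and not true sizes. Compound 4 keeps the hydroxy of compound 2 at 8500 nM and a single chloro, as compound 1 does at 11700 nM.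

A lower number is therefore expected in this assay, and the estimated step is an at least 2.5-fold lower number from compound 3 to compound 4 (0.39 log units; beyond the scatter). Compound 4 is expected at 8000 nM, with an estimated range of 3000 nM to 20000 nM.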

Compound 4, half-maximal inhibitory concentration: 14300 nM
For compound 4 the middle estimate is 1.8-fold (0.25 log units) below the measured one; the range from low to high includes it.
By their numbers in this assay, from the lowest: compounds 2, 1 and 4 (each within the scatter of the next). At a limit, above all of these: compound 3.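

In this assay, 3-chloro-4-hydroxyphenyl in place of 2,4-dichlorophenyl on a double-bonded chain carbon bound to a double-bonded ring carbon gives an at least 1.3-fold lower number from compound 3 to compound 4 (0.14 log units; that floor lies within the scatter). The true size of this step cannot be read because compound 3 stands at a limit of the assay and not at a number: the limit of > 20000 nM in this assay, at which 1 of the 4 values shown sits.

Carrying both a chloro and a hydroxy on the same phenyl does not separate this group from 3-hydroxyphenyl or 2-chlorophenyl at this position, with a 1.7-fold higher number from compound 2 to compound 4 (0.23 log units; within the scatter) and a 1.2-fold higher number from compound 1 to compound 4 (0.09 log units; within the scatter), so these three groups cannot be told apart in this assay.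

From the compounds shown here alone, how far compound 3 really lies from the other compounds remains open, and so does whether the dichloro pattern or some other feature of 2,4-dichlorophenyl accounts for its limit. Going by these compounds, it is also open whether an amine or a carboxylic acid on the phenyl at this position would give a step beyond the scatter from compound 2, compound 1 or compound 4.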